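Furan-2-yl replacing 4-methoxyphenyl on the shared core

This account rests on a few compounds, and the source may have more. Where it says the series, first, only, none or still open, it means among the compounds named here.

Among the measured compounds shown here, compound 2 `COc1ccc(-c2nc(N)c3nc(-c4ccccc4)sc3n2)cc1` gives 46.7 nM in an assay on CHO cells for displacement of a labelled ligand from adenosine receptor A3 (Homo sapiens), read by scintillation counting, with a stated time of 3 h (a higher number here means a weaker inhibitor, a lower number a stronger inhibitor), the higher of the two numbers measured so far. For the measured compounds named here, its nearest neighbour, compound 1 `Nc1nc(-c2ccc(CO)cc2)nc2sc(-c3ccccc3)nc12`, gives 8.2 nM in this assay; the only measured step is a 5.7-fold higher number from compound 1 to compound 2 (0.76 log units; beyond the scatter).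

Compound 3 `Nc1nc(-c2ccco2)nc2sc(-c3ccccc3)nc12` differs from compound 2 in one place: furan-2-yl in place of 4-methoxyphenyl on an aromatic carbon. The change sits on the aromatic carbon between two ring nitrogen atoms of the six-membered ring of the fused system, the same position that carries the aryl group in compound 1 and compound 2.

Going by the values given here, no measured step bears directly on this exchange; the one step measured, from compound 1 to compound 2, concerns only the substituent on the phenyl ring and says nothing about replacing the whole ring by a five-membered one. The exchange removes three heavy atoms and the methoxy group while keeping one hydrogen-bond acceptor. Among the compounds with values here, with no direct precedent, the expectation for compound 3 rests on the spread of the two measured values: a step of a 3.1-fold lower number from compound 2 to compound 3 (0.49 log units; beyond the scatter) is expected for this assay, bringing compound 3 toward the number of compound 1. Compound 3 is therefore estimated at 15 nM, within a range from 4 nM to 60 nM.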

Compound 3, inhibition constant: 2.8 nM
Compound 3: middle estimate off by 5.4-fold (0.73 log units), on the high side; the measured number lies below the stated range.
By their numbers in this assay, from the lowest: compound 3; then compound 1; then compound 2.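

In this assay, the aromatic carbon between two ring nitrogen atoms is not tied to a six-membered aromatic ring of carbon only: the exchange of 4-methoxyphenyl for furan-2-yl, with 5 heavy atoms entering for 8 leaving, gives a 17-fold lower number from compound 2 to compound 3 (1.22 log units; beyond the scatter) and is larger than the earlier step between the two phenyl substituents, a 5.7-fold higher number from compound 1 to compound 2 (0.76 log units; beyond the scatter) in the opposite direction. Among the compounds shown here, the lower number does not depend on the methoxy comparison alone, since the exchange of 4-(hydroxymethyl)phenyl for furan-2-yl gives a 2.9-fold lower number from compound 1 to compound 3 (0.47 log units; beyond the scatter) and leaves compound 3 with the lowest number of the series so far. No measurement shown here explains why furan-2-yl gives the lowest number at this position.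

On these data alone, it remains open whether this result belongs to furan-2-yl in particular, since thiophen-2-yl, furan-3-yl or an unsubstituted phenyl at this carbon would separate the ring size from the ring oxygen. Also open, as far as these compounds go, is whether a methyl or a carboxylic acid on the furan ring would keep the number of compound 3 2.8 nM in this series.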